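Quaternary Anilinium Salts: Methylation of the Phenolic Oxygen

The source may hold more compounds than are shown below. What is called first, only, known or untested is meant among the compounds shown, and "the series" means these compounds.

The set comprises three measured quaternary ammonium compounds and one that awaits measurement. Compound 1 `C=C(C)C[N+](C)(C)c1cccc(O)c1` bears a free hydroxy group on its aromatic ring. In a functional assay with Cavia porcellus as the target (on this read-out lower numbers stand for stronger inhibition and higher numbers for weaker inhibition), compound 1 gives only a limit, > 3000 nM. Compound 2 `C=C(C)C[N+](C)(C)c1cccc(OC)c1` differs from it by methyl in place of hydrogen on an oxygen on an aromatic ring. In this assay compound 2 likewise gives only a limit, > 3000 nM. The resulting step, a step that the two limits leave unreadable from compound 1 to compound 2, cannot be read, since both values sit at the limit of > 3000 nM in this assay, at which 3 of the 3 values shown sit.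

Compound 3 `C[N+](C)(Cc1ccccc1)c1ccccc1O` carries a benzyl group on the nitrogen in place of the methallyl chain of compound 1; how its core differs from that of compound 1 is not broken down here. In this assay compound 3 gives only a limit, > 3000 nM.

Compound 4 `COc1ccccc1[N+](C)(C)Cc1ccccc1` stands to compound 3 exactly as compound 2 stands to compound 1: it differs by methyl in place of hydrogen on an oxygen on an aromatic ring, and the place of the change is the same in both pairs. Among the compounds shown this change occurs twice in all. Among the measured compounds shown here, because every value shown sits at the limit of > 3000 nM in this assay, at which 3 of the 3 values shown sit, no measured step speaks for or against an effect of this change. The expected step from compound 3 to compound 4 is therefore a step that the limit leaves unreadable from compound 3 to compound 4, with no direction supported. The expected value for compound 4 in this assay is 6000 nM, estimated between 2000 nM and 30000 nM, most probably again reported only as a limit.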

Compound 4, half-maximal inhibitory concentration: > 3000 nM
Compound 4: no number, only a limit; the forecaster's own chance of this, stated with the estimate: 85%; the middle value lies beyond the limit too.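

No step can be read from compound 3 to compound 4, just as none could be read from compound 1 to compound 2, since neither pair yields a number in this assay: the limit of > 3000 nM in this assay, at which 4 of the 4 values shown sit. The compounds shown leave open whether the change from hydroxy to methoxy alters inhibition in either pair, and how strongly any of the four compounds inhibits.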